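The source may hold more compounds than are shown below. What is called first, only, known or untested is meant among the compounds shown, and "the series" means these compounds.

Within the data shown here, compound 2 `Nc1cc(N)c2nc(-c3ccccc3)c(NCc3ccc(F)cc3)nc2c1` gives 2630 nM in a functional assay on OVCAR-5 cells (Homo sapiens) for inhibition, read by sulforhodamine B assay, with a stated time of 48 h (a lower number here means a stronger inhibitor of growth, a higher number a weaker inhibitor of growth), the lower of the two numbers so far. Compound 1 `COc1ccc(CNc2nc3cc(N)cc(N)c3nc2-c2ccccc2)cc1OC` gives 20900 nM in this assay, and a 7.9-fold lower number from compound 1 to compound 2 (0.90 log units; beyond the scatter). Compound 3 `COc1ccc(CNc2nc3cc(N)cc(N)c3nc2-c2ccccc2)cc1` carries methoxy in place of fluoro on an aromatic carbon, which restores one of the two methoxy groups that compound 1 bears. Among the measured compounds shown here, only the step from compound 1 to compound 2 bears on this change, and it went the other way, so a higher number is expected for compound 3, though less than the full reversal. Compound 3 is estimated at 7000 nM, range 3000 nM to 18000 nM, meaning a 2.7-fold higher number from compound 2 to compound 3 (0.43 log units; beyond the scatter).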

Compound 3, concentration for 50% growth inhibition: 20900 nM
The estimate for compound 3 lay 3.0-fold (0.48 log units) below the measured number; the whole stated range lies below it.
By their numbers in this assay, from the lowest: compound 2; then compounds 1 and 3 (each within the scatter of the next).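

The change from 4-fluorophenyl to 4-methoxyphenyl alone accounts for the whole difference seen so far, giving a 7.9-fold higher number from compound 2 to compound 3 (0.90 log units; beyond the scatter) in this assay. Removing the second methoxy group adds nothing readable, with no change at the digits printed from compound 1 to compound 3 (within the scatter), so the lower number of compound 2 follows the fluoro group at this place rather than the loss of that extra methoxy group. No measurement on hand explains the difference between fluoro and methoxy here.
From the compounds shown here alone, whether hydrogen, chloro or an amine at this place would read with compound 2 or with compound 3 remains open.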